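The compounds below may be only part of what the source reports. "The series", "measured", "known", "first", "only" and "open" are said of these compounds alone.

Measured compounds:

Compound 1 `CC(=O)OCC[C@@H]1C[C@@H](c2ccc(F)c(F)c2)[C@H](NC(=O)c2cc(-c3c(Cl)cnn3C)c(Cl)o2)CN1`, 4960 nM in a functional assay on OVCAR-8 cells (Homo sapiens) for antiproliferative activity; a higher number here means a weaker inhibitor, a lower number a stronger inhibitor.
Compound 2 `COCC[C@@H]1C[C@@H](c2ccc(Cl)c(Cl)c2)[C@H](NC(=O)c2cc(-c3c(Cl)cnn3C)c(Cl)o2)CN1`, 1060 nM in this assay.
Compound 3 `Cn1ncc(Cl)c1-c1cc(C(=O)N[C@@H]2CN[C@H](CC(O)CO)C[C@H]2c2ccc(F)c(F)c2)oc1Cl`, 690 nM in this assay.

Among these three, compound 2 stands second highest. Its nearest neighbour is compound 3, within the scatter of it; its furthest is compound 1, which is beyond the scatter on the high side. The unmeasured compound 4 `Cn1ncc(Cl)c1-c1cc(C(=O)N[C@@H]2CN[C@H](CC(=O)NCCO)C[C@H]2c2ccc(Cl)c(Cl)c2)oc1Cl` differs from compound 2 in one place: (2-hydroxyethyl)carbamoyl in place of methoxymethyl on a saturated chain carbon bound to a saturated ring carbon.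

For the measured compounds named here, one measured step bears on this position. There, a 7.2-fold lower number from compound 1 to compound 3 (0.86 log units; beyond the scatter), so a change of the group on this chain carbon has moved the number beyond the scatter once, toward a lower value. Going by the values given here, no pair on the shared core measures the present exchange itself, so the step from compound 2 is read as uncertain in size and most likely modest. The estimate for compound 4 is 700 nM, with a range from 250 nM to 2500 nM. This estimate corresponds to an expected step of a 1.5-fold lower number from compound 2 to compound 4 (0.18 log units; within the scatter).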

Compound 4, half-maximal inhibitory concentration: 1450 nM
Estimate against measurement, compound 4: 2.1-fold (0.32 log units) below, and the stated range covers the measured number.
By their numbers in this assay, from the lowest: compounds 3, 2 and 4 (each within the scatter of the next, the first and the last beyond it); then compound 1.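

In this assay, placing (2-hydroxyethyl)carbamoyl in place of methoxymethyl on a saturated chain carbon bound to a saturated ring carbon gives a 1.4-fold higher number from compound 2 to compound 4 (0.14 log units; within the scatter), a step within the scatter. The earlier change on this chain carbon, a 7.2-fold lower number from compound 1 to compound 3 (0.86 log units; beyond the scatter), lay beyond the scatter, whereas this result shows that a change here need not move the number that far, even when the entering group has 6 heavy atoms against 3 and brings hydrogen-bond donors where methoxymethyl has none. Nothing in the data offers an explanation for this outcome.

The compounds shown leave open whether an amine, a carboxylic acid or a longer chain on this chain carbon would move the number beyond the scatter. They also leave open whether the same exchange would give a similar step on the core of compound 1.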